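The compounds below may be only part of what the source reports. "The series", "measured", "known", "first", "only" and "open" are said of these compounds alone.

Measured compounds:
- Compound 1 `Clc1ccc(-c2noc(-c3cc4ccccc4[nH]3)n2)cc1`: in a functional assay on MCF7 cells (Homo sapiens) for antiproliferative activity, read by WST assay, with a stated time of 72 h (a higher number here means a weaker inhibitor, a lower number a stronger inhibitor), compound 1 gives > 50000 nM, which is a limit of the assay and not a number.
- Compound 2 `Clc1ccc(-c2noc(-c3cc4cc(Cl)ccc4[nH]3)n2)cc1`: in this assay compound 2 gives > 50000 nM, again a limit of the assay and not a number.

Compound 2 therefore stands at the limit in this assay; no number is known for it. Among the measured compounds shown here, its only measured neighbour, compound 1, also sits at a limit, so the step that the two limits leave unreadable from compound 1 to compound 2 cannot be read in either direction; both values rest at the same limit (the limit of > 50000 nM in this assay, at which 2 of the 2 values shown sit).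

The step to compound 3 `Cn1c(-c2nc(-c3ccc(Cl)cc3)no2)cc2cc(Cl)ccc21` is methyl in place of hydrogen on an aromatic nitrogen. For the measured compounds named here, no measured step concerns a change at an aromatic nitrogen; the single measured step concerns a chloro and is itself unreadable. No size or direction of step can thus be taken from the measured steps, and the expectation for compound 3 rests only on both measured compounds sitting at the limit in this assay.

Compound 3 is expected at about 50000 nM in this assay, within 10000 nM to 200000 nM, most likely again reported as a limit. This estimate means an expected step of a number no higher from compound 2 to compound 3 (the limit leaves the size open), none beyond the scatter.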

Compound 3, half-maximal inhibitory concentration: > 50000 nM
Compound 3 ended at the assay's limit (the forecaster's own chance of this, stated with the estimate: 80%); the middle value lies on the limit itself.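

Among the compounds shown here, compound 2 and compound 3 both rest at a limit, so no step between them can be read, and the methyl in place of hydrogen on the aromatic nitrogen yields no size or direction: the limit of > 50000 nM in this assay, at which 3 of the 3 values shown sit.

The compounds shown leave open whether either the chloro or the methyl change alters activity in this assay at all.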